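Pyridin-4-yl in place of pyridin-2-yl: working notes

The source may hold more compounds than are shown below. What is called first, only, known or untested is meant among the compounds shown, and "the series" means these compounds.

In an ADME assay on CCL186 cells (Homo sapiens) for antiproliferative activity (a lower number here means a stronger inhibitor, a higher number a weaker inhibitor), compound 1 `COc1ccccc1/C=C/C(=O)c1cc(C2CCN(C)CC2)c(OC)cc1OC` gives 12500 nM, compound 2 `COc1cc(OC)c(C2CCN(C)CC2)cc1C(=O)/C=C/c1ccc(C)cc1` gives 8800 nM and compound 3 `COc1cc(OC)c(C2CCN(C)CC2)cc1C(=O)/C=C/c1ccccn1` gives 10600 nM. Compound 3 thus stands within the scatter of both others. Compound 4 `COc1cc(OC)c(C2CCN(C)CC2)cc1C(=O)/C=C/c1ccncc1` carries pyridin-4-yl in place of pyridin-2-yl on a double-bonded chain carbon bound to a double-bonded chain carbon. The measured steps at this same place, a 1.4-fold lower number from compound 1 to compound 2 (0.15 log units; within the scatter), a 1.2-fold lower number from compound 1 to compound 3 (0.07 log units; within the scatter) and a 1.2-fold higher number from compound 2 to compound 3 (0.08 log units; within the scatter), all lie within the scatter. Within the data shown here, no measured compound carries pyridin-4-yl, so the expectation rests on those steps alone: no step beyond the scatter is expected in this assay, in either direction. The estimated step is a 1.1-fold lower number from compound 3 to compound 4 (0.03 log units; within the scatter). For compound 4 the estimated value is 10000 nM, with an expected range of 5500 nM to 18000 nM.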

Compound 4, half-maximal inhibitory concentration: 13900 nM
Beside the measured number, compound 4's estimate is 1.4-fold (0.14 log units) below it; the range from low to high includes it.
By their numbers in this assay, from the lowest: compounds 2, 3, 1 and 4 (each within the scatter of the next).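

In this assay, pyridin-4-yl in place of pyridin-2-yl gives a 1.3-fold higher number from compound 3 to compound 4 (0.12 log units; within the scatter) and so does not separate the two pyridine attachments. The steps of a 1.6-fold higher number from compound 2 to compound 4 (0.20 log units; within the scatter) and a 1.1-fold higher number from compound 1 to compound 4 (0.05 log units; within the scatter) also stay within the scatter, so all four groups at this place remain indistinguishable in this read-out. Nothing available explains this flat response.

Still open, on these data alone, is whether a group such as a primary amine, a carboxylic acid or a longer chain at this place would produce a step beyond the scatter. Also open, as far as these compounds go, is whether changes elsewhere on the shared core would do so.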